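This account rests on a few compounds, and the source may have more. Where it says the series, first, only, none or still open, it means among the compounds named here.

Series notes. Two compounds of the series carry numbers in a functional assay on RBL-2H3 cells (Rattus norvegicus) for inhibition, with stated times of 10 min and 4 h; a lower number here means a stronger inhibitor, a higher number a weaker inhibitor. Compound 1 `C=C[C@H](OC(C)=O)c1ccc(OC(C)=O)cc1` gives 12000 nM. Compound 2 `CC(=O)Oc1ccc(C(OC(=O)c2ccccc2)c2ccccc2)cc1` gives 23000 nM in this assay, the higher of the two numbers shown, though its gap to compound 1 lies within the scatter of repeated measurements, so the two cannot be put in order on what is known. For the measured compounds named here, no pair of measured compounds differs in a single place, so no measured step is available for the exchange considered here.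

Compound 3 `COC(=O)OC(c1ccccc1)c1ccc(OC(C)=O)cc1` departs from compound 2 in one place: methoxy in place of phenyl on a carbonyl carbon. Nothing measured in this assay bears on this exchange, so the expectation rests on compound 2 and its value of 23000 nM alone. The step from compound 2 to compound 3 is expected to be a 1.2-fold lower number from compound 2 to compound 3 (0.06 log units; within the scatter), that is, no movement beyond the scatter in either direction. Compound 3 is accordingly estimated at 20000 nM in this assay, with a range from 7000 nM to 60000 nM, and a fair chance that the assay returns only a limit at this level.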

Compound 3, half-maximal inhibitory concentration: 12000 nM
Beside the measured number, compound 3's estimate is 1.7-fold (0.22 log units) above it; low and high end bracket the measured number.
By their numbers in this assay, from the lowest: compounds 1, 3 and 2 (each within the scatter of the next).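

In this assay, for the compounds shown here, the exchange of phenyl for methoxy on a carbonyl carbon, which cut one bond further out reads benzoyl to methoxycarbonyl, gives the first measured step: a 1.9-fold lower number from compound 2 to compound 3 (0.28 log units; within the scatter), so compound 2 and compound 3 cannot be put in order. This position therefore accepts a swap in which an aromatic ring of 6 heavy atoms leaves and a ringless group of 2 heavy atoms with a hydrogen-bond acceptor enters, and the step shows no movement beyond the scatter, so the phenyl ring on this carbonyl carbon is not needed to keep the number within the scatter of compound 2. No measurement on hand offers an explanation for this step.

This single step cannot show whether any group on this carbonyl carbon moves the number beyond the scatter in either direction, and a dimethylamino group or a longer chain such as butoxy would test that. It also leaves open whether the same exchange behaves alike on a different core, as a single pair cannot establish a trend for this position.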